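Aryl Groups on a Ring Amine Nitrogen and Receptor Antagonism

This account rests on a few compounds, and the source may have more. Where it says the series, first, only, none or still open, it means among the compounds named here.

Compound 1 `CN(C[C@H]1Cc2c(cccc2N2CCN(C3CC3)CC2)CN1)[C@H]1CCCc2cccnc21`: 23.5 nM
Compound 2 `CN(C[C@H]1Cc2c(cccc2N2CCN(c3ncccn3)CC2)CN1)[C@H]1CCCc2cccnc21`: 30.7 nM
Compound 3 `CN(C[C@H]1Cc2c(cccc2N2CCNCC2)CN1)[C@H]1CCCc2cccnc21`: 6.08 nM

In a functional assay on CCRF-CEM cells for antagonist activity at C-X-C chemokine receptor type 4 (Homo sapiens), read by calcium flux, with stated times of 25 min and 90 s (on this read-out lower numbers stand for stronger inhibition and higher numbers for weaker inhibition), compound 3 gives the lowest number of the three measured compounds; the two steps leading to it are a 3.9-fold lower number from compound 1 to compound 3 (0.59 log units; beyond the scatter) and a 5.0-fold lower number from compound 2 to compound 3 (0.70 log units; beyond the scatter), both beyond the scatter and both modest. The two substituted compounds themselves differ by a 1.3-fold higher number from compound 1 to compound 2 (0.12 log units; within the scatter), which is within the scatter.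

Compound 4 `CN(C[C@H]1Cc2c(cccc2N2CCN(c3ccccn3)CC2)CN1)[C@H]1CCCc2cccnc21` differs from compound 3 by pyridin-2-yl in place of hydrogen on an amine nitrogen in a ring. For the measured compounds named here, the steps that bear on this change are those from compound 3 back to compound 1 and to compound 2: in each, placing a group on that ring nitrogen in place of hydrogen went with a modestly higher number, whether the group was cyclopropyl or pyrimidin-2-yl. Pyridin-2-yl is, like pyrimidin-2-yl, a six-membered aromatic ring on the same nitrogen, so a rise of similar size is expected, namely a 4.3-fold higher number from compound 3 to compound 4 (0.63 log units; beyond the scatter). Compound 4 is accordingly estimated at 26 nM in this assay, with a range from 10 nM to 65 nM.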

Compound 4, half-maximal inhibitory concentration: 17.9 nM
Beside the measured number, compound 4's estimate is 1.5-fold (0.16 log units) above it, within the range that was stated.
By their numbers in this assay, from the lowest: compound 3; then compounds 4, 1 and 2 (each within the scatter of the next).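

In this assay, a third group on the amine nitrogen in the ring can now be set against the hydrogen of compound 3 (a 2.9-fold higher number from compound 3 to compound 4 (0.47 log units; beyond the scatter)). Pyridin-2-yl cannot be told apart on this read-out from pyrimidin-2-yl (a 1.7-fold lower number from compound 2 to compound 4 (0.23 log units; within the scatter)) or from cyclopropyl (a 1.3-fold lower number from compound 1 to compound 4 (0.12 log units; within the scatter)). Across these four compounds, then, all three groups on that nitrogen give higher numbers than hydrogen, and an aromatic ring and a cyclopropyl ring give numbers within the scatter of each other.

The compounds shown leave open whether a longer alkyl chain, an acetyl group or a chain ending in an amine on that nitrogen would also give a higher number than compound 3. Nothing measured here accounts for the rise seen when hydrogen is replaced.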